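Ethyl Ester in Place of Dimethylamide on a Shared Core

This account rests on a few compounds, and the source may have more. Where it says the series, first, only, none or still open, it means among the compounds named here.

Compound 1, `CCC[S+]([O-])c1sc2nc(-c3cccs3)cc(C(=O)O)c2c1N`, gives 71 nM in an assay for inhibition of 15-hydroxyprostaglandin dehydrogenase [NAD(+)] (Homo sapiens), read by fluorescence, with a stated time of 15 min, in the presence of a further agent that is not named here; a lower number here means a stronger inhibitor, a higher number a weaker inhibitor.
Compound 2, `CCC[S+]([O-])c1sc2nc(-c3cccs3)cc(C(=O)N(C)C)c2c1N`, gives 14.7 nM in this assay.
Compound 3, `CCCCSc1sc2nc(-c3cccs3)cc(-c3ccccc3)c2c1N`, gives only a limit of the assay, > 80 nM, in this assay.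

Among the two numbers shown, compound 2 has the lowest, with compound 1 nearest; the step of a 4.8-fold lower number from compound 1 to compound 2 (0.68 log units; beyond the scatter) was modest but beyond the scatter, and it is the only measured step at the carbonyl carbon. Compound 4, `CCC[S+]([O-])c1sc2nc(-c3cccs3)cc(C(=O)OCC)c2c1N`, differs from compound 2 by ethoxy in place of dimethylamino on a carbonyl carbon. This change removes the dimethylamino again but puts an ethoxy, not a hydroxy, in its place, so the number for compound 4 in this assay is expected to rise by less than that earlier step, giving a 2.0-fold higher number from compound 2 to compound 4 (0.31 log units; beyond the scatter). Compound 4 is estimated at 30 nM, within 10 nM to 90 nM.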

Compound 4, half-maximal inhibitory concentration: 2 nM
Compound 4: the middle estimate sits 15-fold (1.18 log units) above what was measured, and the stated range ends above it.
By their numbers in this assay, from the lowest: compound 4; then compound 2; then compound 1. At a limit, above all of these: compound 3.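

In this assay the ethoxy on the carbonyl carbon gives a 7.4-fold lower number from compound 2 to compound 4 (0.87 log units; beyond the scatter) and a 36-fold lower number from compound 1 to compound 4 (1.55 log units; beyond the scatter) and so stands lower than both the dimethylamino and the hydroxy. The earlier compounds shown here showed only that dimethylamino gave a lower number than hydroxy, whereas compound 4 shows that the lowest number so far at this position needs no nitrogen on the carbonyl carbon. Nothing given here bears on why ethoxy and dimethylamino differ in this way.

As far as these compounds go, it remains open whether a longer chain on that oxygen, such as propyl or benzyl, would lower the number further or raise it again. From the compounds shown here alone, a methyl ester and a monomethyl amide at the same carbonyl carbon are equally open.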